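The compounds below may be only part of what the source reports. "The series", "measured", "known", "first", "only" and "open" are said of these compounds alone.

Measured in an ADME assay on Huh-7 cells (Homo sapiens) for cytotoxicity, read by MTT assay, with a stated time of 96 h; on this read-out lower numbers stand for higher toxicity in this test and higher numbers for lower toxicity in this test:
- compound 1 `COc1cc(NCc2ccc(C)o2)ccc1-c1cnco1`: 63400 nM
- compound 2 `COc1cc(NCc2ccncc2)ccc1-c1cnco1`: 72200 nM
- compound 3 `CCc1ccc(CNc2ccc(-c3cnco3)c(OC)c2)s1`: 39100 nM

Compound 3 stands within the scatter of both other compounds. Compound 4 `COc1cc(NCc2ccsc2)ccc1-c1cnco1` carries thiophen-3-yl in place of 5-ethylthiophen-2-yl on a saturated chain carbon bound to a nitrogen on an aromatic ring. Going by the values given here, no measured step covers this exact exchange. Three measured steps change the group at that same place: a 1.1-fold higher number from compound 1 to compound 2 (0.06 log units; within the scatter), a 1.6-fold lower number from compound 1 to compound 3 (0.21 log units; within the scatter) and a 1.8-fold lower number from compound 2 to compound 3 (0.27 log units; within the scatter). As all three stayed within the scatter, no step beyond the scatter is expected in this assay. The expected change is a 1.3-fold higher number from compound 3 to compound 4 (0.11 log units; within the scatter). Compound 4 is estimated at 50000 nM, with an expected range from 25000 nM to 90000 nM.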

Compound 4, half-maximal cytotoxic concentration: 63100 nM
The estimate for compound 4 lay 1.3-fold (0.10 log units) below the measured number, and the stated range covers the measured number.
By their numbers in this assay, from the lowest: compounds 3, 4, 1 and 2 (each within the scatter of the next).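

In (this assay), thiophen-3-yl on a saturated chain carbon bound to a nitrogen on an aromatic ring stays within the scatter of all three earlier groups: replacing 5-ethylthiophen-2-yl gives (a 1.6-fold higher number from compound 3 to compound 4 (0.21 log units; within the scatter)), replacing pyridin-4-yl gives (a 1.1-fold lower number from compound 2 to compound 4 (0.06 log units; within the scatter)), and replacing 5-methylfuran-2-yl gives (a 1.0-fold lower number from compound 1 to compound 4 (0.00 log units; within the scatter)). The read-out at this place thus shows no step beyond the scatter across four groups, including the smaller thiophene without the ethyl group. Nothing at hand explains this result. The compounds shown leave open whether an amine, a carboxylic acid or a longer chain at this place would move the number beyond the scatter.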